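Swapping the aromatic group of compound 2

This account rests on a few compounds, and the source may have more. Where it says the series, first, only, none or still open, it means among the compounds named here.

In a functional assay on K562 cells (Homo sapiens) for cytotoxicity, read by sulforhodamine B assay (on this read-out lower numbers stand for higher toxicity in this test and higher numbers for lower toxicity in this test), compound 1 `CC1=CC[C@@H]([C@@](C)(O)CCCC(C)(C)NC(=S)NN)CC1` gives 9580 nM as its reading. Compound 2 `CC1=CC[C@@H]([C@@](C)(O)CCCC(C)(C)NC(=S)N/N=C\c2ccc(N(C)C)cc2)CC1` stands at > 100000 nM and this is a limit of the assay, not a number. Compound 3 `CC1=CC[C@@H]([C@@](C)(O)CCCC(C)(C)NC(=S)N/N=C\c2cccc(Cl)c2)CC1` carries 3-chlorophenyl in place of 4-(dimethylamino)phenyl on a carbon with a double bond to nitrogen and shares the rest of its structure with compound 2. Among the compounds with values here, no measured step shows what such a swap does. In this assay a modest drop towards higher toxicity is expected, estimated as an at least 3.3-fold lower number from compound 2 to compound 3 (0.52 log units; beyond the scatter) and held loosely. The expected reading for compound 3 is 30000 nM with an estimated range from 6000 nM to 100000 nM on this scale.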

Compound 3, concentration lethal to 50% of the cells: 56300 nM
The estimate for compound 3 lay 1.9-fold (0.27 log units) below the measured number; measured number inside the range.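

With 3-chlorophenyl on the carbon with a double bond to nitrogen, compound 3 gives a true number for a compound with an aromatic group at this position, and this assay shows a 5.9-fold higher number from compound 1 to compound 3 (0.77 log units; beyond the scatter). Swapping in 3-chlorophenyl gives an at least 1.7-fold lower number from compound 2 to compound 3 (0.24 log units; that floor lies within the scatter), so the true size of this swap stays unknown. Compound 2 is held at a limit, not a number: the limit of > 100000 nM in this assay, at which 1 of the 3 values shown sits.

The compounds shown leave open how a plain phenyl or a 4-chlorophenyl would read at this position, and so whether adding the chlorine or removing the dimethylamino group matters more.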